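Shifting a Chlorine on the Aryl Ring of Compound 1

The source may hold more compounds than are shown below. What is called first, only, known or untested is meant among the compounds shown, and "the series" means these compounds.

Measured so far:
compound 1, `C=C(C)[C@H]1CC=C(C)[C@@]2(O)[C@@H]1[C@H](c1cccc(Cl)c1Cl)O[C@@H]2C(=O)OCC`, 5000 nM
compound 2, `C=C(C)[C@H]1CC(=O)C(C)=C2[C@@H](C(=O)OCC)O[C@@H](c3cccc(Br)c3)[C@@H]21`, 30000 nM
compound 3, `C=C(C)[C@H]1CC=C(C)[C@@]2(O)[C@@H]1[C@H](c1ccccc1Br)O[C@@H]2C(=O)O`, > 100000 nM

The read-out is a functional assay on KB3 cells (Homo sapiens) for antiproliferative activity, read by MTT assay, with a stated time of 96 h; on this read-out higher numbers stand for weaker inhibition and lower numbers for stronger inhibition. Of the two numbers reported, compound 1 holds the lower one, and compound 2 stands above it by a margin beyond the usual scatter. For compound 3 the result in this assay is only a limit, (the limit of > 100000 nM in this assay, at which 1 of the 3 values shown sits), and not a number; nothing more is said of it here.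

Compound 4, `C=C(C)[C@H]1CC=C(C)[C@@]2(O)[C@@H]1[C@H](c1ccc(Cl)cc1Cl)O[C@@H]2C(=O)OCC`, has the same atoms as compound 1 joined differently: 2,4-dichlorophenyl in place of 2,3-dichlorophenyl on a saturated ring carbon. Within the data shown here, no measured pair shows what moving a chlorine around the aryl ring does in this assay, so the estimate for compound 4 rests on compound 1 alone. The step from compound 1 to compound 4 is expected to be small, with no direction beyond the scatter, as stated by a 1.2-fold higher number from compound 1 to compound 4 (0.08 log units; within the scatter). Compound 4 is therefore estimated at 6000 nM in this assay, within a range from 1500 nM to 25000 nM.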

Compound 4, half-maximal inhibitory concentration: 3000 nM
For compound 4 the middle estimate is 2.0-fold (0.30 log units) above the measured one; the range from low to high includes it.
By their numbers in this assay, from the lowest: compounds 4 and 1 (each within the scatter of the next); then compound 2. At a limit, above all of these: compound 3.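

Moving a chlorine on the aryl ring gives the first reading of this position in this assay: a 1.7-fold lower number from compound 1 to compound 4 (0.22 log units; within the scatter). Among these compounds, the 2,4-dichlorophenyl and 2,3-dichlorophenyl groups on this saturated ring carbon therefore cannot be told apart here, and the earlier compounds, which differ from one another in more than one place, could not show this. Nothing given here bears on why the two arrangements read alike.

The compounds shown leave open whether this carbon would accept an aryl ring carrying a methoxy group or an amine in place of the chlorines, as they carry only chlorine or bromine on that ring. On these data alone, what the ethoxycarbonyl group contributes on its own also stays open, as compound 2 and compound 3 each differ from compound 1 in more than one place.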